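The compounds below may be only part of what the source reports. "The series", "measured", "known", "first", "only" and "open" are said of these compounds alone.

Two urea compounds built on the same core have been measured in an ADME assay on microsomes from liver (Homo sapiens) for metabolic stability, using NADPH, with a stated time of 60 min; on this read-out lower numbers stand for slow clearance and higher numbers for fast clearance. Compound 1 `O=C(Nc1ccc(F)c(C(F)(F)F)c1)Nc1ccccn1` carries a pyridin-2-yl on one amide-type nitrogen, and in this assay compound 1 gives 188 uL/min. Compound 2 `O=C(Nc1cccnc1)Nc1ccc(F)c(C(F)(F)F)c1` differs only in carrying a pyridin-3-yl at that position, and in this assay compound 2 gives 13 uL/min, the lowest of the two numbers seen so far. The step between them, a 14-fold lower number from compound 1 to compound 2 (1.16 log units; beyond the scatter), is large and well beyond the usual scatter.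

Compound 3 `O=C(Nc1ccncc1)Nc1ccc(F)c(C(F)(F)F)c1` is the next member, and it has not yet been measured. Its difference from compound 2 is pyridin-4-yl in place of pyridin-3-yl on an amide-type nitrogen. Among the measured compounds shown here, the only measured step that bears on this change is the one from compound 1 to compound 2, which showed that moving the ring nitrogen to another position can shift the read-out strongly. For the measured compounds named here, no measured step covers the move from pyridin-3-yl to pyridin-4-yl, so the direction is open. The number for compound 3 in this assay is estimated at 25 uL/min, with a range from 8 uL/min to 80 uL/min. For compound 3 this amounts to an expected step of a 1.9-fold higher number from compound 2 to compound 3 (0.28 log units; within the scatter).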

Compound 3, intrinsic clearance in a liver preparation (reported as CLH), per the amount of preparation that the assay uses in the Homo sapiens assay: 12 uL/min
Compound 3: the middle estimate sits 2.1-fold (0.32 log units) above what was measured; measured number inside the range.
By their numbers in the Homo sapiens assay, from the lowest: compounds 3 and 2 (each within the scatter of the next); then compound 1.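

In the Homo sapiens assay the change from pyridin-3-yl to pyridin-4-yl on the amide-type nitrogen gives a 1.1-fold lower number from compound 2 to compound 3 (0.03 log units; within the scatter), so on this read-out these two placements of the ring nitrogen cannot be told apart, while the comparison with pyridin-2-yl gives a 16-fold lower number from compound 1 to compound 3 (1.19 log units; beyond the scatter), which sets pyridin-2-yl apart from both of the others. In a physicochemical assay for solubility, read by nephelometry, in phosphate buffer, measured as kinetic solubility, at pH 6.5 (a higher number here means a more soluble compound, a lower number a less soluble compound), compound 2 gives 12.5 ug/mL and compound 3 gives 6.3 ug/mL, which amounts to a 2.0-fold lower number from compound 2 to compound 3 (0.30 log units; within the scatter), so this second read-out does not separate the two compounds either. Nothing available here accounts for why only pyridin-2-yl stands apart.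

The compounds shown leave open whether a ring nitrogen is needed at all for a number like those of compound 2 and compound 3 in the Homo sapiens assay, a question that a plain phenyl ring at this place would address. They also leave open how pyridin-2-yl would read in the physicochemical assay, and whether an amine or a carboxylic acid added to the pyridin-4-yl ring would change either read-out.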